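The source may hold more compounds than are shown below. What is called first, only, known or untested is meant among the compounds shown, and "the series" means these compounds.

Measured so far in an assay on isolated protein for displacement of a labelled ligand from metabotropic glutamate receptor 5 (Homo sapiens), with a stated time of 60 min, tested at 1 uM; on this read-out higher numbers stand for more inhibition at the one concentration tested (going by the name of the read-out) and lower numbers for less inhibition:
- compound 1 `Cc1ccc2ncc(S(=O)(=O)c3ccc(Cl)cc3)c(N3CCC(C)CC3)c2c1` gives 79%
- compound 2 `Cc1ccc2ncc(S(=O)(=O)c3ccc(C)c(Cl)c3)c(N3CCC(C)CC3)c2c1` gives 91%
- compound 3 `Cc1ccc2ncc(S(=O)(=O)c3ccc(C)c(F)c3)c(N3CCC(C)CC3)c2c1` gives 91%

Compound 3 stands level with compound 2 at the digits printed, the two together the highest of the three numbers, and above compound 1 by a number 12 percentage points higher from compound 1 to compound 3 (beyond the scatter). Compound 4 `Cc1cc(C)cc(S(=O)(=O)c2cnc3ccc(C)cc3c2N2CCC(C)CC2)c1` differs from compound 3 by 3,5-dimethylphenyl in place of 3-fluoro-4-methylphenyl on a sulfonyl sulfur. For the measured compounds named here, the steps that bear on this are the two changes of the ring on the sulfonyl sulfur, a number 12 percentage points higher from compound 1 to compound 2 (beyond the scatter) and a number 12 percentage points higher from compound 1 to compound 3 (beyond the scatter), while the swap of halogen, no change at the digits printed from compound 2 to compound 3 (within the scatter), leaves the number level. Compound 4 is therefore expected to stay close to compound 3, with a step of a number 6 percentage points lower from compound 3 to compound 4 (within the scatter). The estimate for compound 4 in this assay is 85%, expected between 70% and 95%.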

Compound 4, a percentage reported as inhibition, at one concentration (the size of the read-out at that concentration, not a potency): 80%
The estimate for compound 4 lay 5 percentage points above the measured number; the measured number falls inside the stated range.
By their numbers in this assay, from the lowest: compounds 1 and 4 (each within the scatter of the next); then compounds 2 and 3 (each within the scatter of the next).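

Placing 3,5-dimethylphenyl on the sulfonyl sulfur gives a number 11 percentage points lower from compound 3 to compound 4 (beyond the scatter) and a number 11 percentage points lower from compound 2 to compound 4 (beyond the scatter) in this assay, so this position, indifferent to the swap of halogen, does respond to a change in the ring's substituents. Against 4-chlorophenyl, the same change gives a number 1 percentage points higher from compound 1 to compound 4 (within the scatter) and so opens no gap. Among these four compounds, only compounds 2 and 3, whose rings carry both a halogen and a methyl, hold the higher level.

Nothing available accounts for this difference. Going by these compounds, whether a methoxy group or a nitrile on this ring would hold that higher level remains open.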